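The source may hold more compounds than are shown below. What is called first, only, known or untested is meant among the compounds shown, and "the series" means these compounds.

Among the measured compounds shown here, compound 3, drawn as `CCOC(=O)C1=C(S[C@@H]2CN[C@H](C(=O)Nc3cccc(C(=O)OCC)c3)C2)[C@H](C)[C@@H]2[C@@H]([C@@H](C)OC(=O)CC)C(=O)N12`, is the only member of this small series with a reported number. In an ADME assay on the whole organism (plasma, strain Beagle) for pharmacokinetics, with Canis familiaris (Canis lupus familiaris) as the target, read by LC-MS, with a stated time of 8 h, at a dose of 10 mg/kg by the intraduodenal route (a lower number here means less compound in the circulation, a higher number more compound in the circulation at the dose given), compound 3 gives 940 ng.h/mL. For the measured compounds named here, its two companions were entered without any result in this assay: compound 1 `CCCCOC(=O)C1=C(S[C@@H]2CN[C@H](C(=O)Nc3cccc(C(=O)OCCCC)c3)C2)[C@H](C)[C@@H]2[C@@H]([C@@H](C)O)C(=O)N12` stands at "not determined" (no result reported), and compound 2 `C[C@@H](O)[C@H]1C(=O)N2C(C(=O)OCc3oc(=O)oc3C(C)(C)C)=C(S[C@@H]3CN[C@H](C(=O)Nc4cccc(C(=O)OCc5oc(=O)oc5C(C)(C)C)c4)C3)[C@H](C)[C@H]12` stands at "not determined" (no result reported), so no measured step exists to set the size of a change.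

Compound 4, drawn as `CCOC(=O)C1=C(S[C@@H]2CN[C@H](C(=O)Nc3cccc(C(=O)OCC)c3)C2)[C@H](C)[C@@H]2[C@@H]([C@@H](C)O)C(=O)N12`, differs from compound 3 in one place: hydrogen in place of propanoyl on an oxygen on a saturated carbon. Going by the values given here, with no comparable pair to draw on, the expected step from compound 3 to compound 4 in this assay is judged modest, a fall of about a 1.6-fold lower number from compound 3 to compound 4 (0.19 log units; within the scatter), within reach of the usual scatter. Compound 4 is therefore estimated at 600 ng.h/mL, with a range from 250 ng.h/mL to 1500 ng.h/mL.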

Compound 4, area under the concentration-time curve: 1750 ng.h/mL
Compound 4: the middle estimate sits 2.9-fold (0.46 log units) below what was measured; measured number above the stated range.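

Among the compounds shown here, putting hydrogen in place of propanoyl on this oxygen gives a 1.9-fold higher number from compound 3 to compound 4 (0.27 log units; within the scatter) in this assay, the first measured step. At this position, the propanoyloxy and hydroxy forms therefore cannot be told apart in this read-out, with the ethyl esters held constant. No accompanying measurement explains the result.

On these data alone, it remains open whether an acetyl group or a longer acyl chain such as hexanoyl on the same oxygen would also stay within the scatter. An acyl group carrying an amine is equally untested by these compounds.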